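Substitution on the amide-type nitrogen of the isatin-type core: allyl analogue

The compounds below may be only part of what the source reports. "The series", "measured", "known", "first", "only" and "open" are said of these compounds alone.

Measured so far:
Compound 1, `CCCCc1ccc2c(c1)C(=O)C(=O)N2`. In a functional assay on HepG2 cells (Homo sapiens) for antiproliferative activity, read by MTT assay, with a stated time of 48 h (a lower number here means a stronger inhibitor, a higher number a weaker inhibitor), compound 1 gives > 10000 nM, which is a limit of the assay and not a number.
Compound 2, `COc1ccc(-c2ccc3c(c2)C(=O)C(=O)N3)cc1`. In this assay compound 2 gives 960 nM.
Compound 3, `COc1ccc(-c2ccc3c(c2)C(=O)C(=O)N3C)cc1`. In this assay compound 3 gives 6670 nM.

Among the compounds with values here, compound 3 holds the highest of the two numbers known; its nearest neighbour is compound 2, and the step of a 6.9-fold higher number from compound 2 to compound 3 (0.84 log units; beyond the scatter) lies beyond the scatter. Compound 4, `C=CCN1C(=O)C(=O)c2cc(-c3ccc(OC)cc3)ccc21`, differs from compound 3 by vinyl in place of hydrogen on a saturated chain carbon bound to an amide-type nitrogen in a ring. Within the data shown here, the only measured step that bears on it is a 6.9-fold higher number from compound 2 to compound 3 (0.84 log units; beyond the scatter), a modest rise in the number when the hydrogen on the amide-type nitrogen in the ring was replaced by methyl. Growing that methyl to allyl has no direct precedent in the series, so the expected step of a 1.2-fold higher number from compound 3 to compound 4 (0.08 log units; within the scatter) is small, in the direction of a higher number or none beyond the scatter. Compound 4 is therefore estimated at 8000 nM, with a range from 2500 nM to 25000 nM.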

Compound 4, half-maximal inhibitory concentration: 7090 nM
Compound 4: middle estimate off by 1.1-fold (0.05 log units), on the high side; measured number inside the range.
By their numbers in this assay, from the lowest: compound 2; then compounds 3 and 4 (each within the scatter of the next). At a limit, above all of these: compound 1.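

In this assay, methyl and allyl on the amide-type nitrogen in the ring cannot be told apart: a 1.1-fold higher number from compound 3 to compound 4 (0.03 log units; within the scatter). Set against the amide hydrogen, allyl gives a 7.4-fold higher number from compound 2 to compound 4 (0.87 log units; beyond the scatter), so the higher number seen with methyl recurs with a second group, and in these compounds the hydrogen form alone holds the lower number. No measurement available here accounts for this result.

On these data alone, whether a longer chain, a benzyl group or a chain ending in an amine or a carboxylic acid at this nitrogen would stay level with methyl and allyl remains open. Also open, as far as these compounds go, is whether the same substitution on the nitrogen would give a comparable step with a group other than the methoxyphenyl on the shared core.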